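Replacing a Hydroxyl with Methoxy and a Second Bromine

A few compounds are considered here, and "the series" means these few. Any claim that something is new, unique, unknown or untested is made for them only; others in the source may bear on it.

Compound 3, `O=C(Nc1ccc(Sc2nc3ccccc3s2)c(Cl)c1)c1cccc(Br)c1O`, is the only one of the three measured compounds that yields an actual number in an ADME assay on HEK293 cells (Homo sapiens) for cytotoxicity, read by reporter gene assay and resazurin assay, with a stated time of 48 h; on this read-out higher numbers stand for lower toxicity in this test and lower numbers for higher toxicity in this test: in this assay compound 3 gives 64000 nM. Compound 1, `COc1c(Br)cccc1C(=O)Nc1ccc(Sc2nc3ccccc3s2)c(Cl)c1`, gives only a limit in this assay, > 100000 nM. Compound 2, `COc1c(Br)cc(Br)cc1C(=O)Nc1ccc(Sc2nc3ccccc3s2)cc1`, likewise gives only a limit in this assay, > 100000 nM. Compound 4, `COc1c(Br)cc(Br)cc1C(=O)Nc1ccc(Sc2nc3ccccc3s2)c(Cl)c1`, has not yet been measured. It differs from compound 3 in a single place: a group of 10 heavy atoms (7 carbon, 1 oxygen, 2 bromine; one six-membered aromatic ring of carbon only) in place of a group of 8 heavy atoms (6 carbon, 1 oxygen, 1 bromine; one six-membered aromatic ring of carbon only), on a carbonyl carbon. Going by the values given here, the one measured step that bears on this change runs in the opposite direction: an at least 1.5-fold lower number from compound 1 to compound 3 (0.19 log units; that floor lies within the scatter). Compound 4 restores the methyl on the oxygen and carries a second bromine, so the number is expected to move back up rather than down. Because (the limit of > 100000 nM in this assay, at which 2 of the 3 values shown sit), the most likely outcome for compound 4 is again a limit rather than a number. The estimate for compound 4 in this assay is 150000 nM, in the range 60000 nM to 400000 nM. The expected step upward is a 2.3-fold higher number from compound 3 to compound 4 (0.37 log units; beyond the scatter).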

Compound 4, half-maximal cytotoxic concentration: > 100000 nM
Compound 4: only a limit was reported; the forecaster's own chance of this, stated with the estimate: 75%; the middle value lies beyond the limit too.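

Replacing the 3-bromo-2-hydroxyphenyl group on the carbonyl carbon with the group that has a methyl on the oxygen and a second bromine gives, in this assay, an at least 1.5-fold higher number from compound 3 to compound 4 (0.19 log units; that floor lies within the scatter), so this step alone does not establish a real rise. New here is that the chloro of compound 1 and the second bromine of compound 2 sit together in compound 4, and the read-out is still only a limit: the limit of > 100000 nM in this assay, at which 3 of the 4 values shown sit. The steps from compound 1 and from compound 2 to compound 4 cannot be read, as both ends of each are limits.

The compounds shown leave open which of the two changes in compound 4, the methyl on the oxygen or the second bromine, matters for this read-out. Also open, on these data alone, is what an amine or a carboxylic acid on that aromatic ring would do to the number.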